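Aryl substituent change on the shared core, compound 2 to 3

The source may report more compounds than this note shows. Statements on the series, on what has been measured and on what is new or still open speak of the compounds shown alone.

Compound 1 `COc1cc(-c2cc(-c3ccc(C)cc3)nc(-c3ccccc3)n2)cc(OC)c1OC` and compound 2 `COc1cc(-c2cc(-c3ccccc3)nc(-c3ccccc3)n2)cc(OC)c1OC` share one core and differ only in the group on one aromatic carbon. In a functional assay on MDA-MB-231 cells (Homo sapiens) for inhibition, read by MTT assay, with a stated time of 48 h (a lower number here means a stronger inhibitor, a higher number a weaker inhibitor), compound 1 gives 5110 nM. In this assay compound 2 gives 5870 nM. Compound 2 thus stands highest of the two numbers, with compound 1 nearest and within the scatter of it, so no order between the two can be read.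

Compound 3 `COc1cc(-c2cc(-c3ccc(N)cc3)nc(-c3ccccc3)n2)cc(OC)c1OC` is not yet measured. It differs from compound 2 by amino in place of hydrogen on an aromatic carbon. Going by the values given here, the only measured step that bears on this change is a 1.1-fold higher number from compound 1 to compound 2 (0.06 log units; within the scatter), which sits on the same aromatic carbon and stays within the scatter; no measured step covers an amino group entering. The expected step from compound 2 to compound 3 is therefore a 1.3-fold lower number from compound 2 to compound 3 (0.12 log units; within the scatter), with no direction established. Compound 3 is expected at 4500 nM, with a range from 1800 nM to 11000 nM.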

Compound 3, half-maximal inhibitory concentration: 1010 nM
The estimate for compound 3 lay 4.5-fold (0.65 log units) above the measured number; measured number outside the range, below it.
By their numbers in this assay, from the lowest: compound 3; then compounds 1 and 2 (each within the scatter of the next).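

In this assay, this position on the ring responds to its substituent: amino in place of hydrogen gives a 5.8-fold lower number from compound 2 to compound 3 (0.76 log units; beyond the scatter) and amino in place of methyl gives a 5.1-fold lower number from compound 1 to compound 3 (0.70 log units; beyond the scatter), whereas hydrogen and methyl could not be told apart. Both steps lie beyond the scatter and end at the same compound, so compound 3 is the strongest inhibitor of the three shown, whichever of the two smaller groups the amino group replaces. Nothing available explains this shift.

From the compounds shown here alone, it remains open whether the step is specific to a free amino group or would also appear with hydroxyl, methoxy, dimethylamino or acetamido in the same place. A single amino compound also cannot show whether the step would hold with the amino group elsewhere on this ring.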